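This account rests on a few compounds, and the source may have more. Where it says the series, first, only, none or still open, it means among the compounds named here.

Among the measured compounds shown here, compound 2 `Cc1ccccc1-c1nn(-c2ccc(C(F)(F)F)cc2)cc1CNCCN1CCN(C)CC1` is the only compound with a numerical result here. In an ADME assay on Huh-7 cells (Homo sapiens) for cytotoxicity (a lower number here means that less compound is tolerated, a higher number that more compound is tolerated), compound 2 gives 11000 nM. Compound 1 `CN1CCN(CCNCc2cn(-c3ccc(F)cc3F)nc2C2CCCCC2)CC1` reached only a limit of the assay, not a number: in this assay compound 1 gives > 20000 nM, which matches (the limit of > 20000 nM in this assay, at which 1 of the 2 values shown sits). Compound 3 `Cc1ccccc1-c1nn(-c2ccc(Br)cc2)cc1CNCCN1CCN(C)CC1` differs from compound 2 by bromo in place of trifluoromethyl on an aromatic carbon. For the measured compounds named here, no measured step of this kind exists, so the step is expected to stay within the usual scatter, with no clear direction. Compound 3 is therefore estimated to give 12000 nM in this assay, between 5000 nM and 25000 nM, a step of a 1.1-fold higher number from compound 2 to compound 3 (0.04 log units; within the scatter) from compound 2.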

Compound 3, half-maximal cytotoxic concentration: 9600 nM
The estimate for compound 3 lay 1.3-fold (0.10 log units) above the measured number, and the stated range covers the measured number.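

Among the compounds shown here, the first measured step at this position, a 1.1-fold lower number from compound 2 to compound 3 (0.06 log units; within the scatter), shows that in this assay compound 2 and compound 3 cannot be told apart. On this aromatic carbon, a trifluoromethyl group of 4 heavy atoms and a single bromine atom therefore give results within the usual scatter of each other. Nothing measured here offers a reason for this result.

From the compounds shown here alone, whether an amine or a carboxylic acid at this carbon would also stay within the scatter remains open. So does whether the same swap would give a similar result on a different core.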